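Two halomethyl amides and the methyl they shed

A few compounds are considered here, and "the series" means these few. Any claim that something is new, unique, unknown or untested is made for them only; others in the source may bear on it.

The study compares four acylated benzamide ureas in a functional assay on CCRF-CEM cells (Homo sapiens) for antiproliferative activity, read by trypan blue exclusion, with a stated time of 72 h; on this read-out lower numbers stand for stronger inhibition and higher numbers for weaker inhibition. Compound 1 `COC(=O)c1cc(NC(=O)C(C)Br)cc(C(=O)NC(N)=O)c1` gives 2700 nM there, and compound 2 `COC(=O)c1cc(NC(=O)CBr)cc(C(=O)NC(N)=O)c1` gives 1300 nM. The two differ by hydrogen in place of methyl on a saturated chain carbon bound to a bromine atom and a carbonyl carbon, a change that brought a 2.1-fold lower number from compound 1 to compound 2 (0.32 log units; beyond the scatter).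

Compound 3 `Cc1ccc(C(=O)NC(N)=O)cc1NC(=O)C(C)Cl` sits on a different core; how its core differs from that of compound 1 is not broken down here. In this assay compound 3 reaches only the limit of the measurement, > 20000 nM, a limit described as the limit of > 20000 nM in this assay, at which 1 of the 3 values shown sits.

Compound 4 `Cc1ccc(C(=O)NC(N)=O)cc1NC(=O)CCl` is the partner of compound 3 and has not yet been measured. It differs from compound 3 by hydrogen in place of methyl on a saturated chain carbon bound to a carbonyl carbon and a chlorine atom. This is the same kind of change as that from compound 1 to compound 2, though not the same: in compound 3 the saturated chain carbon is bound to a chlorine atom, whereas in compound 1 it is bound to a bromine atom.

Set beside a 2.1-fold lower number from compound 1 to compound 2 (0.32 log units; beyond the scatter), the step expected from the removal of the methyl in this second pair is an at least 1.3-fold lower number from compound 3 to compound 4 (0.12 log units; that floor lies within the scatter); that expectation rests on the single measured step and on the fact that compound 3 gave only a limit, so the starting point itself is not pinned down. On that basis compound 4 is expected to give about 15000 nM, estimated to lie between 5000 nM and 40000 nM, with a real chance that this assay again reports only a limit.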

Compound 4, half-maximal inhibitory concentration: 3360 nM
The estimate for compound 4 lay 4.5-fold (0.65 log units) above the measured number; the whole stated range lies above it.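

In this assay, hydrogen in place of methyl on the saturated chain carbon again goes with a lower number, this time an at least 5.9-fold lower number from compound 3 to compound 4 (0.77 log units; beyond the scatter), so the direction of the change carries over from one core to the other in these two pairs. The size of the step does not carry over, as the two steps set together show: the same change on two cores in this assay, a 2.1-fold lower number (0.32 log units; beyond the scatter) from compound 1 to compound 2 and an at least 5.9-fold lower number (0.77 log units; beyond the scatter) from compound 3 to compound 4, at least 2.8-fold (0.45 log units) apart, beyond the scatter of two such steps. This does not show whether the core or the halogen, a bromine atom in the first pair and a chlorine atom in the second, accounts for the gap, and the second step has only a floor, as compound 3 gave a limit of the assay and not a number: the limit of > 20000 nM in this assay, at which 1 of the 4 values shown sits.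

The compounds shown leave open how the same change behaves with a bromine atom on the core of compound 3 or a chlorine atom on the core of compound 1, the pairings that would separate the two differences. They also leave open whether an ethyl group in place of the methyl, or an amine in place of the halogen, would fit the same direction on either core.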